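Swapping a Pyridin-4-yl Cap for an Ethylamino Group

A few compounds are considered here, and "the series" means these few. Any claim that something is new, unique, unknown or untested is made for them only; others in the source may bear on it.

Three compounds that share a core and differ only at one carbonyl carbon have been measured in an assay on isolated protein for binding affinity to secreted frizzled-related protein 1 (Homo sapiens), read by fluorescence; a higher number here means a weaker inhibitor, a lower number a stronger inhibitor. Compound 1 `CC(C)(C)OC(=O)N1CCC[C@H]1C(=O)N1CCC(NS(=O)(=O)c2cc(S(=O)(=O)c3ccccc3)ccc2C(F)(F)F)CC1` gives 60 nM in this assay. Compound 2 `CN(C)CC(=O)N1CCC[C@H]1C(=O)N1CCC(NS(=O)(=O)c2cc(S(=O)(=O)c3ccccc3)ccc2C(F)(F)F)CC1` gives 90 nM in this assay. Compound 3 `O=C([C@@H]1CCCN1C(=O)c1ccncc1)N1CCC(NS(=O)(=O)c2cc(S(=O)(=O)c3ccccc3)ccc2C(F)(F)F)CC1` gives 70 nM in this assay. On these numbers compound 3 stands second highest of the three, but none of the three is separated from another by more than the scatter: the step of a 1.2-fold higher number from compound 1 to compound 3 (0.07 log units; within the scatter) and the step of a 1.3-fold lower number from compound 2 to compound 3 (0.11 log units; within the scatter) are both within it, as is the step of a 1.5-fold higher number from compound 1 to compound 2 (0.18 log units; within the scatter) between the other two.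

Compound 4 `CCNC(=O)N1CCC[C@H]1C(=O)N1CCC(NS(=O)(=O)c2cc(S(=O)(=O)c3ccccc3)ccc2C(F)(F)F)CC1` is the next member of the series. Relative to compound 3 the change is ethylamino in place of pyridin-4-yl on a carbonyl carbon. Among the measured compounds shown here, the three measured steps all sit on this same carbonyl carbon, and each of them moved the number by less than the scatter, so nothing so far shows this position to be sensitive to what is attached there. The expectation for compound 4 in this assay is therefore no step beyond the scatter, in either direction. The estimated step is no change at the digits printed from compound 3 to compound 4 (within the scatter). Compound 4 is expected to give about 70 nM, within a range of 35 nM to 140 nM.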

Compound 4, half-maximal inhibitory concentration: 30 nM
The estimate for compound 4 lay 2.3-fold (0.37 log units) above the measured number; measured number below the stated range.
By their numbers in this assay, from the lowest: compounds 4, 1, 3 and 2 (each within the scatter of the next, the first and the last beyond it).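

In this assay, among the compounds shown here, this carbonyl carbon now shows that it can respond to the group it carries: ethylamino gives a 2.3-fold lower number from compound 3 to compound 4 (0.37 log units; beyond the scatter) and a 3.0-fold lower number from compound 2 to compound 4 (0.48 log units; beyond the scatter), both modest but beyond the scatter, whereas none of the earlier steps at this place went beyond it. The response is limited, however, and compound 1 goes against any claim that ethylamino stands apart from every other group tried here: a 2.0-fold lower number from compound 1 to compound 4 (0.30 log units; within the scatter) still lies within the scatter, so tert-butoxy and ethylamino cannot be told apart on these numbers. Nothing available here accounts for the steps that do exceed the scatter.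

The compounds shown leave open whether the step depends on the hydrogen on the ethylamino nitrogen, a question that dimethylamino attached directly to this carbonyl carbon would put to the test. They also leave open how far the chain itself matters, since methylamino, a longer chain such as butylamino, or a cyclic amine such as pyrrolidin-1-yl at this place could each show whether the size of the group on that nitrogen moves the number in this assay at all.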